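Adding chloro to compound 2: an expected limit

The compounds below may be only part of what the source reports. "The series", "measured", "known", "first", "only" and "open" are said of these compounds alone.

compound 1 `Cc1cc(Nc2cccc(Cl)c2)nc(N)n1`: > 180000 nM
compound 2 `Cc1cc(Nc2ccccc2C)nc(N)n1`: > 180000 nM

Of the compounds shown here, two have been measured in an assay on cells for inhibition of S-adenosylmethionine decarboxylase proenzyme (Homo sapiens), read by mass spectrometry, at pH 7.2; on this read-out lower numbers stand for stronger inhibition and higher numbers for weaker inhibition. Compound 1 `Cc1cc(Nc2cccc(Cl)c2)nc(N)n1` gives > 180000 nM, which is a limit of the assay and not a number. Compound 2 `Cc1cc(Nc2ccccc2C)nc(N)n1` gives > 180000 nM in this assay, again a limit rather than a number. Compound 2 therefore stands nowhere on a scale of numbers: both values sit at the limit of > 180000 nM in this assay, at which 2 of the 2 values shown sit.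

Compound 3 `Cc1cc(Nc2cc(Cl)ccc2C)nc(N)n1` has not yet been measured. It differs from compound 2 by chloro in place of hydrogen on an aromatic carbon. Within the data shown here, no step between measured compounds is available, so no measured change in this assay can be quoted for adding a chloro. The expectation for compound 3 is that the value again sits at a limit, with no movement beyond the scatter, and the expected step is a step that the limit leaves unreadable from compound 2 to compound 3. Compound 3 is estimated at 200000 nM, within 60000 nM to 700000 nM.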

Compound 3, half-maximal inhibitory concentration: > 180000 nM
Compound 3: no number, only a limit; the forecaster's own chance of this, stated with the estimate: 80%; the middle value is on the limit's open side.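

In this assay, among these compounds, compound 3 gives a limit and not a number, so no step from compound 1 or compound 2 to compound 3 can be read: the limit of > 180000 nM in this assay, at which 3 of the 3 values shown sit. The compounds shown leave open how strongly, if at all, any of the three inhibits.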